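The compounds below may be only part of what the source reports. "The series", "measured", "known", "first", "only" and "open" are said of these compounds alone.

Compound 1, `CCCCCc1ccc(C#Cc2cn(C/C=C\CN3C(=O)c4ccccc4C3=O)c(=O)[nH]c2=O)cc1`, in a functional assay on MCF7 cells (Homo sapiens) for antiproliferative activity, read by MTT assay, with a stated time of 3 days (a lower number here means a stronger inhibitor, a higher number a weaker inhibitor), gives > 100000 nM, which is a limit of the assay rather than a number.
Compound 2, `CCCCc1ccc(C#Cc2cn(C/C=C/CN3C(=O)c4ccccc4C3=O)c(=O)[nH]c2=O)cc1`, in this assay gives 44000 nM.

Compound 2 thus holds the only measured number shown; the other entry sits at the limit (the limit of > 100000 nM in this assay, at which 1 of the 2 values shown sits). Compound 3, `CCCCc1ccc(C#Cc2cn(C/C=C\CN3C(=O)c4ccccc4C3=O)c(=O)[nH]c2=O)cc1`, keeps every atom and bond of compound 2 and differs only in configuration: the two compounds have the same atoms and bonds and differ only in configuration as drawn: 1 of 1 stereo elements differ; a double bond is drawn E in compound 2 and Z in compound 3. Among the compounds with values here, no measured pair isolates this flip of the double bond, so the size of its effect is open. A weakening is expected, a 2.0-fold higher number from compound 2 to compound 3 (0.31 log units; beyond the scatter). Compound 3 is estimated at 90000 nM, with a range from 30000 nM to 300000 nM.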

Compound 3, half-maximal inhibitory concentration: 43000 nM
Beside the measured number, compound 3's estimate is 2.1-fold (0.32 log units) above it, and the stated range covers the measured number.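

In this assay, the double bond can be drawn either way without a readable change: a 1.0-fold lower number from compound 2 to compound 3 (0.01 log units; within the scatter). With the Z double bond kept, hydrogen in place of methyl on the saturated chain gives an at least 2.3-fold lower number from compound 1 to compound 3 (0.36 log units; beyond the scatter). Compound 1 gives > 100000 nM, a limit of the assay, so the true size of that step stays unknown: the limit of > 100000 nM in this assay, at which 1 of the 3 values shown sits.

Going by these compounds, whether a hexyl chain, or an amine in place of the butyl chain, would lower the number remains open. So does whether the E and Z forms also match when the chain is pentyl.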